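The compounds below may be only part of what the source reports. "The series", "measured", "known", "first", "only" and "open" are said of these compounds alone.

Measured so far: compound 1 `Cc1cc(Oc2ccc(Cn3nc4ccc(Cl)cc4c3C(=O)NS(=O)(=O)c3ccc(NCc4ccncc4)c([N+](=O)[O-])c3)cc2)cc(C)c1Cl` gives 1520 nM in an assay on isolated protein for inhibition of Apoptosis regulator Bcl-2 (Homo sapiens), read by fluorescence polarization; a lower number here means a stronger inhibitor, a higher number a weaker inhibitor; compound 2 `Cc1cc(Oc2ccc(Cn3nc4ccc(Cl)cc4c3C(=O)NS(=O)(=O)c3ccc([N+](=O)[O-])c(NCc4ccco4)c3)cc2)cc(C)c1Cl` gives 960 nM in this assay.

Compound 2 has the lower of the two numbers, yet its gap to compound 1 lies within the scatter, so no order can be read from the pair. Compound 3 `Cc1cc(Oc2ccc(Cn3nc4ccc(Cl)cc4c3C(=O)NS(=O)(=O)c3ccc([N+](=O)[O-])c(NCc4ccn(C)n4)c3)cc2)cc(C)c1Cl` differs from compound 2 by 1-methyl-1H-pyrazol-3-yl in place of furan-2-yl on a saturated chain carbon bound to a nitrogen on an aromatic ring. For the measured compounds named here, no measured pair shows this change, and with one five-membered aromatic ring standing in for another, compound 3 is expected to move little, with a step of a 1.0-fold higher number from compound 2 to compound 3 (0.02 log units; within the scatter) that stays within the scatter. Compound 3 is estimated at 1000 nM, ranging from 400 nM to 2500 nM.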

Compound 3, inhibition constant: 710 nM
Beside the measured number, compound 3's estimate is 1.4-fold (0.15 log units) above it, and the stated range covers the measured number.
By their numbers in this assay, from the lowest: compounds 3, 2 and 1 (each within the scatter of the next, the first and the last beyond it).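

In this assay, 1-methyl-1H-pyrazol-3-yl in place of furan-2-yl on a saturated chain carbon bound to a nitrogen on an aromatic ring gives a 1.4-fold lower number from compound 2 to compound 3 (0.13 log units; within the scatter). The two five-membered aromatic rings therefore cannot be told apart at this position, even though the entering group carries an extra hetero atom and a methyl. Nothing available bears on the reason for this. Going by these compounds, what stays open is how a primary amine or a carboxylic acid would read on this saturated chain carbon, and whether a longer chain would take the number beyond the scatter.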